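This account rests on a few compounds, and the source may have more. Where it says the series, first, only, none or still open, it means among the compounds named here.

Measured values in a functional assay on MCF7 cells (Homo sapiens) for inhibition; on this read-out lower numbers stand for stronger inhibition of growth and higher numbers for weaker inhibition of growth:
- Compound 1 `CN(C)c1ccc(NS(=O)(=O)c2c(F)c(F)c(F)c(F)c2F)cc1`: 34 nM
- Compound 2 `Cc1ccc(NS(=O)(=O)c2c(F)c(F)c(F)c(F)c2F)cc1C`: 120 nM
- Compound 3 `O=S(=O)(Nc1ccc2c(c1)OCCO2)c1c(F)c(F)c(F)c(F)c1F`: 430 nM

Compound 1 has the lowest number of the three and is the strongest inhibitor of growth here. Its gaps to compound 2 and compound 3 both lie beyond the scatter. Compound 4 `COc1ccc(NS(=O)(=O)c2c(F)c(F)c(F)c(F)c2F)cc1` has methoxy in place of dimethylamino on an aromatic carbon. Within the data shown here, no two measured compounds differ in one place only, so this swap has no direct precedent. Compound 2 at 120 nM and compound 3 at 430 nM both lack dimethylamino, and both sit higher, so a moderate rise beyond the scatter is expected. The expected step is a 2.9-fold higher number from compound 1 to compound 4 (0.47 log units; beyond the scatter). For compound 4 the estimated value is 100 nM, with an expected range of 35 nM to 300 nM.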

Compound 4, concentration for 50% growth inhibition: 29 nM
Compound 4: middle estimate off by 3.4-fold (0.54 log units), on the high side; measured number outside the range, below it.
By their numbers in this assay, from the lowest: compounds 4 and 1 (each within the scatter of the next); then compound 2; then compound 3.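

In this assay, placing methoxy in place of dimethylamino on the aromatic carbon para to a large group gives a 1.2-fold lower number from compound 1 to compound 4 (0.07 log units; within the scatter), so the two groups cannot be told apart here. Dimethylamino is therefore not needed for a low number at this position, something the earlier compounds, which each differ from compound 1 in more than one place, could not show. Nothing available explains why the two groups match. On these data alone, whether a carboxylic acid or a longer chain such as butoxy would also hold the number at this position remains open.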